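The source may hold more compounds than are shown below. What is called first, only, known or untested is meant among the compounds shown, and "the series" means these compounds.

Notes on the series. In a functional assay on MDA-MB-231 cells (Homo sapiens) for cytotoxicity, read by MTT assay, with a stated time of 24 h (on this read-out higher numbers stand for weaker inhibition and lower numbers for stronger inhibition), compound 1 `COC(=O)c1ccc(-c2nc3cccnc3n2C2CCCC2)cc1` gives 350 nM and compound 2 `COc1ccc(-c2nc3cccnc3n2C2CCCC2)cn1` gives 219 nM. Within the data shown here, these two values lie within the usual scatter of each other, so compound 1 has no separation from the only other measured compound. Compound 3 `c1cncc(-c2ccc(-c3nc4cccnc4n3C3CCCC3)cc2)c1` is still to be measured. It carries pyridin-3-yl in place of methoxycarbonyl on an aromatic carbon, para to a large group: pyridin-3-yl in place of methoxycarbonyl on an aromatic carbon. Among the measured compounds shown here, no measured pair shows a change at this place, so the direction in this assay cannot be read from the data, and no step beyond the scatter is expected. That expectation starts from compound 1 at 350 nM. The estimated step is a 1.3-fold lower number from compound 1 to compound 3 (0.10 log units; within the scatter). For compound 3 the expected value is 280 nM, with an estimated range from 90 nM to 850 nM.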

Compound 3, half-maximal inhibitory concentration: > 10000 nM
Compound 3: no number, only a limit; the forecaster's own chance of this, stated with the estimate: 3%; middle value at least 35-fold (1.55 log units) from the limit.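

Pyridin-3-yl in place of methoxycarbonyl on an aromatic carbon, para to a large group, gives an at least 28-fold higher number from compound 1 to compound 3 (1.45 log units; beyond the scatter) in this assay and is the first step in the series beyond the scatter, so the group at this place can decide whether the series registers in this assay at all. Compound 3 gives > 10000 nM as a limit of the assay and not a number, so the step has a floor but no measured size. The result for compound 3 rests on a limit alone: the limit of > 10000 nM in this assay, at which 1 of the 3 values shown sits.

The single swap replaces a group without a ring by an aromatic ring, and the compounds shown do not separate these two features. Going by these compounds, whether a carboxylic acid, an amide or a plain phenyl at this place would stay near compound 1 remains open.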